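Swapping fluorine for chlorine on the sulfonyl-bearing ring

The source may report more compounds than this note shows. Statements on the series, on what has been measured and on what is new or still open speak of the compounds shown alone.

Of the compounds shown here, two from this series have been measured in an ADME assay on microsomes from liver (Homo sapiens) for metabolic stability, tested at 2.5 uM; a higher number here means faster removal of the compound, a lower number slower removal. Compound 1 `COc1cccc(-c2c(S(=O)(=O)c3cc(Cl)cc(Cl)c3)cnc3c(F)cccc23)c1` gives 2.31 mL/min in this assay. Compound 2 `O=S(=O)(c1cc(F)cc(F)c1)c1cnc2c(F)cccc2c1-c1ccc(Cl)cc1` gives 0.73 mL/min in this assay, the lowest of the two numbers; compound 1 sits at a number that is beyond the usual scatter above it, so the two are truly distinct in how quickly they are removed. Compound 1 and compound 2 differ in more than one place, so their gap cannot be tied to any single change.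

Compound 3 `O=S(=O)(c1cc(Cl)cc(Cl)c1)c1cnc2c(F)cccc2c1-c1ccc(Cl)cc1` has not yet been measured. It differs from compound 2 in one place only: 3,5-dichlorophenyl in place of 3,5-difluorophenyl on a sulfonyl sulfur. The result is a compound that shares the sulfonyl-bearing ring of compound 1 and the other ring of compound 2.

Among the compounds with values here, with no single-change step between measured compounds to lean on, the direction of the change is uncertain, and the expected step from compound 2 to compound 3 in this assay is a modest rise, a 1.8-fold higher number from compound 2 to compound 3 (0.25 log units; within the scatter), that may or may not exceed the scatter. Compound 3 is therefore expected to give about 1.3 mL/min in this assay, with a range from 0.6 mL/min to 2.8 mL/min.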

Compound 3, intrinsic clearance in a liver preparation (reported as CLH), per the amount of preparation that the assay uses: 0.78 mL/min
For compound 3 the middle estimate is 1.7-fold (0.22 log units) above the measured one; measured number inside the range.
By their numbers in this assay, from the lowest: compounds 2 and 3 (each within the scatter of the next); then compound 1.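

In this assay, 3,5-dichlorophenyl in place of 3,5-difluorophenyl on a sulfonyl sulfur gives a 1.1-fold higher number from compound 2 to compound 3 (0.03 log units; within the scatter), so with the 4-chlorophenyl group present, these two rings on the sulfur cannot be told apart in this measurement. Within the data shown here, compound 3 also supplies the first single-change comparison that clearly moves the read-out: with 3,5-dichlorophenyl kept on the sulfur, 4-chlorophenyl in place of 3-methoxyphenyl on an aromatic carbon gives a 3.0-fold lower number from compound 1 to compound 3 (0.47 log units; beyond the scatter). In this small set, then, the change on the aromatic carbon shifts the number beyond the scatter, whereas the change on the sulfonyl sulfur does not, although each rests on a single pair of compounds, and the data offer no explanation for either result.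

The compounds shown cannot separate the effect of swapping methoxy for chlorine from that of moving the substituent around the ring, a question that 3-chlorophenyl or 4-methoxyphenyl on the same aromatic carbon would address. As far as these compounds go, it also remains open whether the sulfonyl position would stay equally unresponsive with 3-methoxyphenyl present, or with a plain phenyl or a pyridine ring on the sulfur.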